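A few compounds are considered here, and "the series" means these few. Any claim that something is new, unique, unknown or untested is made for them only; others in the source may bear on it.

Three hydrazone compounds were tested in a functional assay on HepG2 cells (Homo sapiens) for cytotoxicity, with a stated time of 24 h; a lower number here means a stronger inhibitor, a higher number a weaker inhibitor. Compound 1 `O=C(N/N=C/c1cc(I)cc(I)c1O)c1ccc(Br)cc1` gives 22300 nM in this assay. Compound 2 `O=C(N/N=C/c1cc(I)cc(I)c1O)c1ccc(I)cc1` carries the change (iodo in place of bromo on an aromatic carbon), and in this assay compound 2 gives 31800 nM, so that the step of a 1.4-fold higher number from compound 1 to compound 2 (0.15 log units; within the scatter) stays small. Compound 3 `O=C(N/N=C/c1cc(I)c(O)c(I)c1)c1ccc(Br)cc1` has the same atoms as compound 1 joined differently; the difference between the two cores is not broken down here. In this assay compound 3 reaches only a limit, > 50000 nM, which is the same limit as the limit of > 50000 nM in this assay, at which 1 of the 3 values shown sits, and not a number.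

Compound 4 `O=C(N/N=C/c1cc(I)c(O)c(I)c1)c1ccc(I)cc1` is not yet measured. For the measured compounds named here, it differs from compound 3 by iodo in place of bromo on an aromatic carbon, the same change as the one between compound 1 and compound 2. Because the measured step of a 1.4-fold higher number from compound 1 to compound 2 (0.15 log units; within the scatter) lies within the scatter, a step that the limit leaves unreadable from compound 3 to compound 4 is expected from compound 3 to compound 4. Since compound 3 already sits at the limit > 50000 nM, compound 4 is expected to give about 80000 nM in this assay, between 40000 nM and 200000 nM, most likely reported again only as a limit.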

Compound 4, half-maximal inhibitory concentration: > 50000 nM
Compound 4 gave a limit, no number (the forecaster's own chance of this, stated with the estimate: 80%); the middle value does not contradict the limit.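

In this assay, compound 3 and compound 4 each give only a limit and not a number, so no step between them can be read: the limit of > 50000 nM in this assay, at which 2 of the 4 values shown sit.

The compounds shown leave open whether iodo in place of bromo changes anything on the core of compound 3, and how far that core stands from the core of compound 1.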